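Reversing the amide of a thiazolyl aminopyridine series

The source may report more compounds than this note shows. Statements on the series, on what has been measured and on what is new or still open speak of the compounds shown alone.

Compound 1, `Cc1ccc(Sc2cnc(Nc3ccccn3)s2)cc1C(=O)NC(C)C`: 2000 nM
Compound 2, `Cc1ccc(Sc2cnc(Nc3ccccn3)s2)cc1C(=O)NCC#N`: 44 nM
Compound 3, `Cc1ccc(Sc2cnc(Nc3cccc(Br)n3)s2)cc1C(=O)N(C)CCC#N`: 10 nM

Of the compounds shown here, three have been measured in an assay on isolated protein for inhibition of high affinity nerve growth factor receptor (Homo sapiens); a higher number here means a weaker inhibitor, a lower number a stronger inhibitor. Compound 2 stands second of the three numbers: compound 3 sits closer, with a lower number, and compound 1 sits furthest, with a much higher one. For the measured compounds named here, the one single-point step seen so far, a 45-fold lower number from compound 1 to compound 2 (1.66 log units; beyond the scatter), changed only the group on the amide nitrogen while leaving the amide itself in place.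

Compound 4, `Cc1ccc(Sc2cnc(Nc3ccccn3)s2)cc1NC(=O)CC#N`, is built from the same atoms as compound 2 but joined differently: ((cyanomethyl)carbonyl)amino in place of (cyanomethyl)carbamoyl on an aromatic carbon. The amide linkage is turned around, so the ring now carries the nitrogen rather than the carbonyl. Going by the values given here, no measured step addresses such a reversal; the step from compound 1 to compound 2 concerns the substituent, not the direction of the amide, and compound 3 differs from compound 2 in several places at once. The size and direction of the change are therefore uncertain, and a moderate shift to a higher number is expected, a 3.4-fold higher number from compound 2 to compound 4 (0.53 log units; beyond the scatter). Compound 4 is estimated at 150 nM, within 30 nM to 1000 nM.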

Compound 4, half-maximal inhibitory concentration: 60 nM
Compound 4: middle estimate off by 2.5-fold (0.40 log units), on the high side, within the range that was stated.
By their numbers in this assay, from the lowest: compound 3; then compounds 2 and 4 (each within the scatter of the next); then compound 1.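

In this assay, turning the amide around on this aromatic carbon, ortho to a methyl group, gives a 1.4-fold higher number from compound 2 to compound 4 (0.13 log units; within the scatter), so with the cyanomethyl group in place the two directions of the linkage cannot be told apart at this position. The reversed amide also keeps a wide separation from the isopropyl amide, with a 33-fold lower number from compound 1 to compound 4 (1.52 log units; beyond the scatter), although that step changes both the direction of the linkage and the group it carries. No supporting measurement bears on this result.

Still open, from the compounds shown here alone, is whether the reversed linkage would tolerate an isopropyl group, as the cyanomethyl version does, or a longer chain such as cyanoethyl, or whether a sulfonamide could replace the amide. The several differences between compound 3 and compound 2 also remain unseparated, so none can yet be applied to compound 4.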